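Second chloro on the fused ring: maximal response expected steady

The source may report more compounds than this note shows. Statements on the series, on what has been measured and on what is new or still open speak of the compounds shown alone.

Measured compounds and their maximal responses:
compound 1 `CC#C[C@@H](CC(=O)O)c1ccc(OC[C@H]2COc3ccc(Cl)cc3O2)cc1` gives 86%
compound 2 `CC#C[C@H](CC(=O)O)c1ccc(OC[C@H]2COc3ccc(Cl)cc3O2)cc1` gives 47%
compound 3 `CC#C[C@@H](CC(=O)O)c1ccc(OC[C@H]2COc3ccc(F)cc3O2)cc1` gives 86%

In a functional assay on HEK293 cells for agonist activity at Free fatty acid receptor 1 (Homo sapiens), read by fluorescence and calcium flux, with a stated time of 10 min (on this read-out higher numbers stand for larger maximal responses and lower numbers for smaller maximal responses), compound 1 stands level with compound 3 at the digits shown, and the two together are the highest of the three numbers. Compound 2 lies far lower: the step of a number 39 percentage points lower from compound 1 to compound 2 (beyond the scatter) is large and beyond the scatter, and it rests on (the fact that compounds 1 and 2 differ only in the configuration as drawn). The step of no change at the digits printed from compound 1 to compound 3 (within the scatter) shows that exchanging one halogen for another on the fused ring left the maximal response untouched.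

Compound 4 `CC#C[C@@H](CC(=O)O)c1ccc(OC[C@H]2COc3cc(Cl)c(Cl)cc3O2)cc1` is the next member. Against compound 1 the change is chloro in place of hydrogen on an aromatic carbon.

Among the compounds with values here, no measured step adds a group to the fused ring, so the only guide is that a halogen swap there, from compound 1 to compound 3, changed nothing, while the configuration at the chain carbon, from compound 1 to compound 2, changed much. Since the configuration is the same in compound 4 as in compound 1, the expected step is a number 4 percentage points lower from compound 1 to compound 4 (within the scatter), no change beyond the scatter. Compound 4 is therefore estimated at 82%, between 62% and 98%.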

Compound 4, largest response reached (Emax), in percent of the reference or control that the assay uses: 33%
Beside the measured number, compound 4's estimate is 49 percentage points above it; measured number below the stated range.
By their numbers in this assay, from the lowest: compound 4; then compound 2; then compounds 1 and 3 (each within the scatter of the next).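

This position is not indifferent to substitution: in this assay, adding one chloro on the aromatic carbon ortho to the existing chloro group gives a number 53 percentage points lower from compound 1 to compound 4 (beyond the scatter). Exchanging the halogen already on that ring gave no change at the digits printed from compound 1 to compound 3 (within the scatter), so one halogen swap there was tolerated, while this added chloro, a single heavy atom with no net charge, was not. Nothing measured here explains why this addition lowers the maximal response.

On these data alone, it remains open whether the loss is specific to chloro or would follow any added group at this carbon, such as fluoro, methyl or methoxy. As far as these compounds go, it is also open whether a chloro here would have the same effect without the existing chloro group on the ring.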